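Swapping the pyridine arm for a quinoline on a shared core

The compounds below may be only part of what the source reports. "The series", "measured", "known", "first", "only" and "open" are said of these compounds alone.

Measured so far:
- compound 1, `O=C1N=C(N2CCC[C@H]2C(=O)Nc2ccc3ncnc(Nc4cccc(Cl)c4)c3c2)S/C1=C/c1cccnc1`: 10400 nM
- compound 2, `O=C1N=C(N2CCC[C@H]2C(=O)Nc2ccc3ncnc(Nc4cccc(Cl)c4)c3c2)S/C1=C/c1cccc(Br)n1`: 3100 nM
- compound 3, `O=C1N=C(N2CCC[C@H]2C(=O)Nc2ccc3ncnc(Nc4cccc(Cl)c4)c3c2)S/C1=C/c1ccccc1[N+](=O)[O-]`: > 50000 nM

In a functional assay on A549 cells (Homo sapiens) for antiproliferative activity, read by MTT assay (a higher number here means a weaker inhibitor, a lower number a stronger inhibitor), compound 1 gives 10400 nM. Among the numbers shown, compound 1 stands highest, and only compound 2 offers a second number to set beside it. For compound 3 the assay reports only a limit, (the limit of > 50000 nM in this assay, at which 1 of the 3 values shown sits), and not a number.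

Compound 4, `O=C1N=C(N2CCC[C@H]2C(=O)Nc2ccc3ncnc(Nc4cccc(Cl)c4)c3c2)S/C1=C/c1ccc2ccccc2n1`, differs from compound 1 in one place: quinolin-2-yl in place of pyridin-3-yl on a double-bonded chain carbon bound to a double-bonded ring carbon. The measured steps that bear on this change both alter the same position. The step of a 3.4-fold lower number from compound 1 to compound 2 (0.53 log units; beyond the scatter) shows that a ring bearing its nitrogen beside the attachment point lowered the number, while an at least 4.8-fold higher number from compound 1 to compound 3 (0.68 log units; beyond the scatter) shows that a nitrogen-free ring carrying a nitro group raised it beyond the limit. A quinolin-2-yl keeps the nitrogen arrangement of compound 2, so a modest drop in this assay from compound 1 is expected, roughly the size seen for compound 2. The step of a 2.3-fold lower number from compound 1 to compound 4 (0.36 log units; beyond the scatter) is the expected result. For compound 4 the estimate is 4500 nM, ranging from 1500 nM to 15000 nM.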

Compound 4, half-maximal inhibitory concentration: > 50000 nM
Compound 4: no number, only a limit; the forecaster's own chance of this, stated with the estimate: 10%; at least 11-fold (1.04 log units) between middle value and limit.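

this assay gives compound 4 only a limit, not a number: the limit of > 50000 nM in this assay, at which 2 of the 4 values shown sit.

The step of an at least 4.8-fold higher number from compound 1 to compound 4 (0.68 log units; beyond the scatter), together with an at least 16-fold higher number from compound 2 to compound 4 (1.20 log units; beyond the scatter), shows that a nitrogen in the attached ring does not by itself bring the lower number seen with 6-bromopyridin-2-yl, and that quinolin-2-yl falls in with the nitrogen-free 2-nitrophenyl of compound 3 instead. The step between compound 3 and compound 4 cannot be read, as both stop at a limit.

Compound 4 differs from compound 2 both in lacking the bromine and in carrying an extra six-membered aromatic ring of carbon only, so the compounds shown cannot say which of the two matters. A plain pyridin-2-yl, or one with a methyl or an amine where the bromine stands, would help to separate them.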